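Two Methyls on the Outer Ring of Compound 2

A few compounds are considered here, and "the series" means these few. Any claim that something is new, unique, unknown or untested is made for them only; others in the source may bear on it.

Of the compounds shown here, three sharing one core have been measured in a functional assay on CHO cells for agonist activity at Free fatty acid receptor 1 (Homo sapiens), read by FLIPR, tested at 100 nM; a lower number here means a weaker effect, a higher number a stronger effect of the compound at the concentration tested. Compound 1 `O=C(O)COc1ccc(NC(=O)COc2ccccc2)cc1F` gives 29.8%, compound 2 `CC(Oc1ccccc1)C(=O)Nc1ccc(OCC(=O)O)c(F)c1` gives 35.7%, and compound 3 `CC(Oc1cccc(C(F)(F)F)c1)C(=O)Nc1ccc(OCC(=O)O)c(F)c1` gives 12.7%. For the measured compounds named here, no measured compound stands clearly above compound 2: compound 1 lies within the scatter of it, as a number 5.9 percentage points higher from compound 1 to compound 2 (within the scatter) shows, while compound 3 lies beyond it, lower, as a number 23 percentage points lower from compound 2 to compound 3 (beyond the scatter) shows.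

Compound 4 `Cc1cc(C)cc(OC(C)C(=O)Nc2ccc(OCC(=O)O)c(F)c2)c1` differs from compound 2 by 3,5-dimethylphenyl in place of phenyl on an oxygen on a saturated carbon. Going by the values given here, the only step that touches this same ring is a number 23 percentage points lower from compound 2 to compound 3 (beyond the scatter), a modest drop; the step of a number 5.9 percentage points higher from compound 1 to compound 2 (within the scatter) sits elsewhere and is within the scatter. A small fall or no change is therefore expected. Compound 4 is estimated at 26%, between 8% and 44%. That estimate means an expected step of a number 9.7 percentage points lower from compound 2 to compound 4 (within the scatter).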

Compound 4, a percentage reported as activity, at one concentration (the size of the read-out at that concentration, not a potency): 25.7%
Compound 4: the middle estimate sits 0.3 percentage points above what was measured; measured number inside the range.
By their numbers in this assay, from the lowest: compound 3; then compounds 4, 1 and 2 (each within the scatter of the next).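

Two methyls on the outer ring, giving 3,5-dimethylphenyl in place of phenyl, produce a number 10 percentage points lower from compound 2 to compound 4 (within the scatter) in this assay. This differs from the trifluoromethyl change on the same ring, which gave a number 23 percentage points lower from compound 2 to compound 3 (beyond the scatter), so at least one substitution on this ring is tolerated within the usual scatter of the assay. Nothing available explains why these two changes read differently. As far as these compounds go, what a methoxy or a chloro group on this outer ring would do stays open. So does whether a single methyl would read like the pair.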